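The compounds below may be only part of what the source reports. "The series", "measured", "known", "first", "only" and "open" are said of these compounds alone.

In a functional assay on NPC-TW01 cells (Homo sapiens) for inhibition, read by MTT assay, with a stated time of 72 h (a lower number here means a stronger inhibitor of growth, a higher number a weaker inhibitor of growth), compound 1 (`Cc1ccc(-c2cc(N)n(-c3ccc(Br)cc3)n2)cc1`) gives 80200 nM and compound 2 (`Nc1cc(-c2ccc(Cl)cc2)nn1-c1ccc(Br)cc1`) gives 64400 nM. Among the measured compounds shown here, the step of a 1.2-fold lower number from compound 1 to compound 2 (0.10 log units; within the scatter) lies within the scatter, so compound 2 stands level with the only other compound that has a number. For the measured compounds named here, compound 3 (`Cc1ccc(-c2nn(-c3cccc(Cl)c3)c(N)c2C=O)cc1`), the only measured compound with a formyl group, gives > 100000 nM, which is a limit of the assay and not a number. Compound 4 (`Nc1c(C=O)c(-c2ccc(Cl)cc2)nn1-c1ccc(Br)cc1`) is compound 2 with formyl in place of hydrogen on an aromatic carbon. Going by the values given here, no measured step isolates this change. Among the compounds with values here, with compound 3 at > 100000 nM as the only guide, a small shift towards a higher number in this assay is expected. The estimated change is a 1.4-fold higher number from compound 2 to compound 4 (0.15 log units; within the scatter). For compound 4 the expected value is 90000 nM, with an estimated range of 30000 nM to 200000 nM.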

Compound 4, concentration for 50% growth inhibition: 59700 nM
Beside the measured number, compound 4's estimate is 1.5-fold (0.18 log units) above it; the measured number falls inside the stated range.
By their numbers in this assay, from the lowest: compounds 4, 2 and 1 (each within the scatter of the next). At a limit, above all of these: compound 3.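

In this assay, formyl in place of hydrogen on this aromatic carbon gives a 1.1-fold lower number from compound 2 to compound 4 (0.03 log units; within the scatter), so this position takes a formyl group with no readable change in growth inhibition. Among the compounds shown here, this is the first step that measures the change directly, and compound 4 gives a number. Compound 3 also carries a formyl group, but its value is a limit and not a number, so it could not show this: the limit of > 100000 nM in this assay, at which 1 of the 4 values shown sits.

As far as these compounds go, whether a carboxylic acid or an amine on this same carbon would move the number beyond the scatter stays open.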